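A few compounds are considered here, and "the series" means these few. Any claim that something is new, unique, unknown or untested is made for them only; others in the source may bear on it.

Measured so far:
Compound 1 `COc1cc(N2CCN(CC3CCOC3)CC2)ccc1Nc1nc(NC2CCCCC2)c2nc[nH]c2n1`: 66 nM
Compound 2 `COc1cc(N2CCC(C(=O)N3CCC(N(C)C)C3)CC2)ccc1Nc1nc(NC2CCCCC2)c2nc[nH]c2n1`: 58 nM

In a functional assay on HCT-116 cells (Homo sapiens) for cytotoxicity (on this read-out lower numbers stand for stronger inhibition and higher numbers for weaker inhibition), compound 2 gives 58 nM. Going by the values given here, that number lies within the usual scatter of the one for compound 1 at 66 nM, so the two cannot be told apart on this read-out.

The next molecule, compound 3 `COc1cc(N2CCC(C(=O)N3CC(O)C3)CC2)ccc1Nc1nc(NC2CCCCC2)c2nc[nH]c2n1`, keeps the shared core and the carbonyl carbon of compound 2 but swaps the group on that carbon: 3-hydroxyazetidin-1-yl in place of 3-(dimethylamino)pyrrolidin-1-yl on a carbonyl carbon. In short, 3-hydroxyazetidin-1-yl stands in place of 3-(dimethylamino)pyrrolidin-1-yl.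

Among the compounds with values here, no pair of measured compounds differs by one change alone, so the data offer no direct guide to the size of this step. Compound 1 at 66 nM and compound 2 at 58 nM carry quite different side groups on the shared core, yet their numbers stay close, which argues against expecting a large jump. A modest move toward weaker inhibition is expected, though it may not clear the scatter, and the estimate is a 1.7-fold higher number from compound 2 to compound 3 (0.24 log units; within the scatter). For compound 3 the expected value is 100 nM, with an estimated range from 35 nM to 300 nM.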

Compound 3, half-maximal inhibitory concentration: 50 nM
Compound 3: the middle estimate sits 2.0-fold (0.30 log units) above what was measured, and the stated range covers the measured number.
By their numbers in this assay, from the lowest: compounds 3, 2 and 1 (each within the scatter of the next).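

Going by these compounds alone, this is the first comparison here in which only one place differs. On a carbonyl carbon, 3-hydroxyazetidin-1-yl in place of 3-(dimethylamino)pyrrolidin-1-yl gives in this assay a step of a 1.2-fold lower number from compound 2 to compound 3 (0.06 log units; within the scatter), so the two compounds cannot be told apart on this read-out. Within the data shown here, the exchange is a large one on paper, as a group of 8 heavy atoms with a five-membered ring and 0 hydrogen-bond donors gives way to one of 5 heavy atoms with a four-membered ring and 1 hydrogen-bond donor, yet this read-out registers no difference between this pair. No measurement offers an explanation for that result.

As far as these compounds go, the ring size, the hydroxyl group and the dimethylamino group all change in this one step, so their separate contributions remain unknown. From the compounds shown here alone, it also remains open whether the same carbonyl carbon would give a similar number with a different group, such as morpholin-4-yl, or with a longer open chain, such as a 2-(dimethylamino)ethylamino group.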